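The compounds below may be only part of what the source reports. "The series", "measured", "known", "first", "only" and "open" are said of these compounds alone.

Compound 1 `Oc1cc(C(F)(F)F)ccc1-c1nc(-c2ccccc2O)n(-c2ccc(F)cc2)n1`: in a functional assay on PC-12 cells (Rattus norvegicus) for cytotoxicity, read by MTT assay, with stated times of 2 h and 24 h, tested at 10 uM (a higher number here means a stronger effect of the compound at the concentration tested, a lower number a weaker effect), compound 1 gives 99.8%.
Compound 2 `Oc1cc(C(F)(F)F)ccc1-c1nc(-c2ccccc2O)n(-c2ccc(Cl)cc2)n1`: in this assay compound 2 gives 96.1%.

Among the measured compounds shown here, both compounds sit near the top of the percentage scale, and the only step that separates them, a number 3.7 percentage points lower from compound 1 to compound 2 (within the scatter), lies within the scatter, so compound 2 stands together with compound 1 rather than apart from it. The one place where the two differ is the halogen on the phenyl ring, and that is again the place at which compound 3 `Oc1cc(C(F)(F)F)ccc1-c1nc(-c2ccccc2O)n(-c2ccc(I)cc2)n1` differs from compound 2: iodo in place of chloro on an aromatic carbon. For the measured compounds named here, the single measured step that bears on this change is the halogen exchange a number 3.7 percentage points lower from compound 1 to compound 2 (within the scatter), which did not move the number beyond the scatter. On this ground the step from compound 2 to compound 3 in this assay is expected to be small, in either direction or none at all beyond the scatter, which means an expected step of a number 1.1 percentage points lower from compound 2 to compound 3 (within the scatter). Compound 3 is therefore estimated to give 95% in this assay, with a range from 80% to 100%.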

Compound 3, a percentage reported as activity, at one concentration (the size of the read-out at that concentration, not a potency): 105%
Beside the measured number, compound 3's estimate is 10 percentage points below it; the whole stated range lies below it.
By their numbers in this assay, from the lowest: compounds 2, 1 and 3 (each within the scatter of the next).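

In this assay the exchange of chloro for iodo gives a number 8.9 percentage points higher from compound 2 to compound 3 (within the scatter) and the exchange of fluoro for iodo gives a number 5.2 percentage points higher from compound 1 to compound 3 (within the scatter) so this position has now carried three different halogens without any pair of them being separated beyond the scatter. What compounds 1 and 2 showed for a single exchange therefore extends to the 4-iodophenyl compound, and among fluoro, chloro and iodo on this aromatic carbon, para to a large group, the choice of halogen leaves the read-out at one level within the scatter. No measurement shown accompanies these compounds that would account for this level result.

On these data alone, all three compounds carry a halogen at this place, so it stays open what an amine, a carboxylic acid or a longer chain there would do to the number. Also open is whether the same level result would hold with the trifluoromethyl group or the two hydroxyl groups of the shared core replaced, since every compound shown keeps them unchanged.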